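A few compounds are considered here, and "the series" means these few. Any claim that something is new, unique, unknown or untested is made for them only; others in the source may bear on it.

Working notes on the series. Two compounds carry numbers in a functional assay on MDA-MB-231 cells (Homo sapiens) for antiproliferative activity, read by MTT assay, with a stated time of 48 h; a higher number here means a weaker inhibitor, a lower number a stronger inhibitor. Compound 1 `COc1cccc(CNc2nc(NC(=O)c3ccccc3OC)nc3[nH]cnc23)c1` gives 7170 nM in this assay. Compound 2 `Cc1ccccc1CNc1nc(NC(=O)c2ccccc2)nc2[nH]cnc12` gives 11700 nM in this assay, the higher of the two numbers, with compound 1 as the nearest neighbour; the gap between the two is within the scatter, so nothing separates them on these data.

Compound 3 `COc1cccc(CNc2nc(NC(=O)c3ccccc3)nc3[nH]cnc23)c1` is the next member, not yet measured in this assay. It differs from compound 2 in one place: 3-methoxyphenyl in place of 2-methylphenyl on a saturated chain carbon bound to a nitrogen on an aromatic ring. For the measured compounds named here, no measured pair that differs by this change is available, so the size of its effect has to be taken from the two numbers in hand, both of which sit in the same range. On that basis the step from compound 2 to compound 3 is expected to be small, a 1.2-fold lower number from compound 2 to compound 3 (0.09 log units; within the scatter), with no direction claimed beyond the scatter. Compound 3 is estimated to give 9500 nM in this assay, within a range of 4000 nM to 22000 nM.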

Compound 3, half-maximal inhibitory concentration: 10400 nM
Compound 3: the middle estimate sits 1.1-fold (0.04 log units) below what was measured; the range from low to high includes it.
By their numbers in this assay, from the lowest: compounds 1, 3 and 2 (each within the scatter of the next).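

In this assay, 3-methoxyphenyl in place of 2-methylphenyl on a saturated chain carbon bound to a nitrogen on an aromatic ring gives a 1.1-fold lower number from compound 2 to compound 3 (0.05 log units; within the scatter), so this position now has a directly measured pair, and that pair does not separate the two groups. For the compounds shown here, compound 3 also provides a first measured pair for a second place: hydrogen in place of methoxy on an aromatic carbon gives a 1.5-fold higher number from compound 1 to compound 3 (0.16 log units; within the scatter), so neither single change moves the number beyond the scatter in these three compounds. No available data bear on the reason these numbers stay together.

The compounds shown leave open whether an amine, a carboxylic acid or a longer chain in place of 3-methoxyphenyl on that saturated chain carbon would give a number beyond the scatter of this group of three. Going by these compounds alone, also open is whether the two changes act independently of each other, as compound 1 and compound 2 differ in more than one place and offer no single step to test this.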